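Chlorophenyl for methylphenyl on the shared core

The source may report more compounds than this note shows. Statements on the series, on what has been measured and on what is new or still open speak of the compounds shown alone.

For the measured compounds named here, compound 1 `Cc1cccc(-c2nc(CNc3ccc(C(=O)NO)cc3)n(-c3ccccc3)n2)c1` stands highest of the three numbers so far in an assay on Sf9 cells for inhibition of protein deacetylase HDAC6 (Homo sapiens), read by fluorescence, with a stated time of 40 min, tested at 100 nM (a lower number here means less inhibition, a higher number more inhibition at the concentration tested (going by the name of the read-out)), where compound 1 gives 64.1%. Compound 3 `COc1ccc(-n2nc(-c3ccccc3)nc2CNc2ccc(C(=O)NO)cc2)cc1` gives 63.4% and compound 2 `Cc1ccccc1-n1nc(-c2ccccc2)nc1CNc1ccc(C(=O)NO)cc1` gives 57.1%, and both lie within the scatter of compound 1, so no order among the three can be read. Going by the values given here, the one measured step, a number 6.3 percentage points higher from compound 2 to compound 3 (within the scatter), exchanges a group on the aromatic nitrogen, not on the aromatic carbon altered here, so it bears only loosely on the move to compound 4 `O=C(NO)c1ccc(NCc2nc(-c3ccccc3Cl)nn2-c2ccccc2)cc1`, which differs from compound 1 by 2-chlorophenyl in place of 3-methylphenyl on an aromatic carbon. Among the compounds with values here, with no step measured on that aromatic carbon, one expects a number 4.1 percentage points lower from compound 1 to compound 4 (within the scatter) to remain within the scatter. Compound 4 is therefore estimated at 60%, between 45% and 75%.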

Compound 4, a percentage reported as inhibition, at one concentration (the size of the read-out at that concentration, not a potency): 75%
Compound 4: middle estimate off by 15 percentage points, on the low side; the range from low to high includes it.
By their numbers in this assay, from the lowest: compounds 2, 3 and 1 (each within the scatter of the next); then compound 4.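

In this assay, the aromatic carbon between two ring nitrogen atoms turns out to be a place where the read-out can shift: the step is a number 10.9 percentage points higher from compound 1 to compound 4 (beyond the scatter) for 2-chlorophenyl in place of 3-methylphenyl, modest in size. For the compounds shown here, the earlier compounds showed no step beyond the scatter, and their one step lay on the aromatic nitrogen. Nothing at hand accounts for this step.

Open, from the compounds shown here alone, is how 2-methylphenyl or 3-chlorophenyl would read on this carbon, which would separate the effect of the chlorine from that of its ring position. Also open, going by these compounds, is how a phenyl ring bearing an amine or a carboxylic acid would read there.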